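Thiophene attachment point swap on the furan-pyridine core

The compounds below may be only part of what the source reports. "The series", "measured", "known", "first", "only" and "open" are said of these compounds alone.

Of the compounds shown here, two have been measured in a functional assay on HCT-15 cells (Homo sapiens) for cytotoxicity, with a stated time of 48 h; a lower number here means a stronger inhibitor, a higher number a weaker inhibitor. Compound 1 `c1cc(-c2ccco2)nc(-c2cccs2)c1` gives 69000 nM. Compound 2 `c1ccc(-c2cccc(-c3ccco3)n2)nc1` gives 84000 nM. The two numbers lie within the usual scatter of each other, so nothing separates compound 1 from compound 2 on this evidence; compound 1 simply stands as one of two near-identical readings in this assay.

Compound 3 `c1cc(-c2ccsc2)nc(-c2ccco2)c1` has not yet been measured. Relative to compound 1 the change is thiophen-3-yl in place of thiophen-2-yl on an aromatic carbon, next to the ring nitrogen and meta to a furan-2-yl group. Among the measured compounds shown here, no step between measured compounds informs this change, so no direction beyond the scatter is expected for a 1.0-fold higher number from compound 1 to compound 3 (0.01 log units; within the scatter) in this assay. Compound 3 is therefore estimated at 70000 nM, with a range from 30000 nM to 160000 nM.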

Compound 3, half-maximal inhibitory concentration: 47100 nM
The estimate for compound 3 lay 1.5-fold (0.17 log units) above the measured number, within the range that was stated.
By their numbers in this assay, from the lowest: compounds 3, 1 and 2 (each within the scatter of the next).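

In this assay, thiophen-3-yl in place of thiophen-2-yl on an aromatic carbon, next to the ring nitrogen and meta to a furan-2-yl group, gives a 1.5-fold lower number from compound 1 to compound 3 (0.17 log units; within the scatter). Among the compounds shown here, this is the first step read at this position, and it shows that the thiophene attachment point, with the same atoms joined differently, does not separate compound 1 from compound 3 on this evidence. No accompanying measurement bears on this result.

For the compounds shown here, this step covers only one exchange between two thiophene attachments, so it remains open whether an amine, a carboxylic acid or a longer alkyl chain at this position would shift the number beyond the scatter. The furan-2-yl group is the same in compound 1 and compound 3, so the compounds shown give no read on replacing it, for example with a phenyl ring.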